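Benzyloxime series: methyl on the benzyl ring

This account rests on a few compounds, and the source may have more. Where it says the series, first, only, none or still open, it means among the compounds named here.

Three compounds have numbers in a functional assay on HepG2 cells (Homo sapiens) for cytotoxicity, read by MTT assay, with a stated time of 2 days; a lower number here means a stronger inhibitor, a higher number a weaker inhibitor. Compound 1 `CC(=O)Nc1ccc2c(c1)/C(=N\O)C(c1c[nH]c3ccc(NC(C)=O)cc13)=N2` gives 28200 nM in this assay. Compound 2 `c1ccc(CO/N=C2/C(c3c[nH]c4ccccc34)=Nc3ccccc32)cc1` gives 19500 nM in this assay. Compound 3 `Fc1ccc2c(c1)/C(=N\OCc1ccccc1)C(c1c[nH]c3ccc(F)cc13)=N2` gives 17300 nM in this assay. Compound 2 thus holds the second highest of the three numbers, but its gap to compound 3 and its gap to compound 1 both lie within the scatter, so the three numbers read as one level rather than as an order.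

Compound 4 `Cc1ccc(CO/N=C2/C(c3c[nH]c4ccccc34)=Nc3ccccc32)cc1` differs from compound 2 by methyl in place of hydrogen on an aromatic carbon, para to a large group, so that the benzyloxy becomes (4-methylbenzyl)oxy. For the measured compounds named here, no measured pair in the set shows this change, and the set gives no step beyond the scatter at all. The expected step from compound 2 to compound 4 in this assay is therefore a 1.1-fold lower number from compound 2 to compound 4 (0.03 log units; within the scatter), that is, none beyond the scatter. Compound 4 is estimated at 18000 nM in this assay, with a range from 8000 nM to 45000 nM.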

Compound 4, half-maximal inhibitory concentration: 19100 nM
Estimate against measurement, compound 4: 1.1-fold (0.03 log units) below; the measured number falls inside the stated range.
By their numbers in this assay, from the lowest: compounds 3, 4, 2 and 1 (each within the scatter of the next).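

In this assay, for the compounds shown here, the change from benzyloxy to (4-methylbenzyl)oxy gives a 1.0-fold lower number from compound 2 to compound 4 (0.01 log units; within the scatter) and provides the first step between compounds that differ in one place. Methyl in place of hydrogen on this aromatic carbon, para to a large group, therefore leaves the number of compound 2 unchanged within the scatter, so this position accepts the added carbon without a readable shift. No measurement available here accounts for the size of this step.

Going by these compounds, it remains open whether an amine, a carboxylic acid or a longer chain at this position would move the number beyond the scatter. On these data alone, it also remains open whether methyl gives the same result elsewhere on the benzyl ring, or on the fluorine-bearing core of compound 3.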